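Aryl variation on a pyrazole carboxylic acid series

The compounds below may be only part of what the source reports. "The series", "measured", "known", "first", "only" and "open" are said of these compounds alone.

Compound 1 `COc1cncc(-c2c(C)nn(-c3nc(-c4ccc(Cl)c(Cl)c4)c(SC(C)C)s3)c2C(=O)O)c1`: 21000 nM
Compound 2 `Cc1cc(C#N)cc(-c2c(C)nn(-c3nc(-c4ccc(Cl)c(Cl)c4)c(SC(C)C)s3)c2C(=O)O)c1`: 4800 nM
Compound 3 `Cc1nn(-c2nc(-c3ccc(Cl)c(Cl)c3)c(SC(C)C)s2)c(C(=O)O)c1-c1cccc(Cl)c1C`: 5100 nM

Three compounds share one core and differ only in the aryl group on the five-membered ring. In a functional assay on BJAB cells (Homo sapiens) for antiproliferative activity, with a stated time of 4 days (a lower number here means that less compound is needed, a higher number that more compound is needed for the effect), compound 1 gives 21000 nM, the highest number of the three. Compound 3 stands second highest: its nearest neighbour is compound 2, and the two values lie within the scatter of each other, while the change a 4.1-fold lower number from compound 1 to compound 3 (0.61 log units; beyond the scatter) is beyond the scatter, as is a 4.4-fold lower number from compound 1 to compound 2 (0.64 log units; beyond the scatter).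

Compound 4 `COc1cccc(-c2c(C)nn(-c3nc(-c4ccc(Cl)c(Cl)c4)c(SC(C)C)s3)c2C(=O)O)c1` is not yet measured. It differs from compound 3 in one place: 3-methoxyphenyl in place of 3-chloro-2-methylphenyl on an aromatic carbon. Among the measured compounds shown here, two measured steps bear on this. The replacement of the pyridyl group of compound 1 by a substituted phenyl ring lowered the number by a 4.1-fold lower number from compound 1 to compound 3 (0.61 log units; beyond the scatter), and the swap between two substituted phenyl rings, a 1.1-fold higher number from compound 2 to compound 3 (0.03 log units; within the scatter), stayed within the scatter. The new group keeps the phenyl ring but carries a methoxy group, which is the group that compound 1 also bears on its pyridyl ring. The expectation is therefore a step of a 1.6-fold higher number from compound 3 to compound 4 (0.20 log units; within the scatter) of modest size toward a higher number, likely at the edge of the scatter rather than well beyond it. For compound 4 in this assay the estimate is 8000 nM, with a range from 3000 nM to 22000 nM.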

Compound 4, half-maximal effective concentration: 14000 nM
For compound 4 the middle estimate is 1.8-fold (0.24 log units) below the measured one; measured number inside the range.
By their numbers in this assay, from the lowest: compounds 2 and 3 (each within the scatter of the next); then compounds 4 and 1 (each within the scatter of the next).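

In this assay, placing 3-methoxyphenyl on this aromatic carbon of the five-membered ring gives a 2.7-fold higher number from compound 3 to compound 4 (0.44 log units; beyond the scatter) and a 2.9-fold higher number from compound 2 to compound 4 (0.46 log units; beyond the scatter), so a phenyl ring here does not in itself bring the lower numbers of compound 2 and compound 3. Against the pyridyl group, the change gives a 1.5-fold lower number from compound 1 to compound 4 (0.18 log units; within the scatter), so no difference can be read between the two methoxy-bearing rings, and among these four compounds, with none going against it, the values fall into two groups: the rings carrying methoxy in compound 1 and compound 4, and the rings carrying methyl in compound 2 and compound 3. Nothing measured here accounts for this division.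

The compounds shown leave open whether the methoxy group, the missing methyl group or the missing chlorine or nitrile decides the outcome, as the ring of compound 4 differs from those of compound 2 and compound 3 in more than one substituent. Also open, from the compounds shown here alone, is how an unsubstituted phenyl ring, a 3-methylphenyl ring or a 3-aminophenyl ring would read at this position.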